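The compounds below may be only part of what the source reports. "The series", "measured", "known", "first", "only" and "open" are said of these compounds alone.

Measured compounds:
compound 1 `COc1ccc([C@@H]2CC(=O)c3c(O)cc(OCc4cn(Cc5ccccc5F)nn4)cc3O2)cc1O` gives 7320 nM in a functional assay on RAW264.7 cells (Mus musculus) for inhibition, read by Griess assay, with stated times of 2 h and 24 h; on this read-out lower numbers stand for stronger inhibition and higher numbers for weaker inhibition
compound 2 `COc1ccc([C@@H]2CC(=O)c3c(O)cc(OCc4cn(C5CCCC5)nn4)cc3O2)cc1O` gives 10500 nM
compound 3 `COc1ccc([C@@H]2C/C(=N\O)c3c(O)cc(OCc4cn(Cc5ccccc5Cl)nn4)cc3O2)cc1O` gives 13400 nM

Compound 1 holds the lowest of the three numbers; the nearest is compound 2 and the furthest compound 3, both within the scatter, so no ranking among the three can be drawn. Compound 4 `COc1ccc([C@@H]2CC(=O)c3c(O)cc(OCc4cn(Cc5cccc(Cl)c5)nn4)cc3O2)cc1O` differs from compound 1 in one place: 3-chlorophenyl in place of 2-fluorophenyl on a saturated chain carbon bound to an aromatic nitrogen. For the measured compounds named here, the only measured step that touches the group on the aromatic nitrogen is a 1.4-fold higher number from compound 1 to compound 2 (0.16 log units; within the scatter), a larger swap than the present one, and it stays within the scatter. Compound 3 differs from compound 1 in more than one place, so only the two values can be set side by side, and they too fall within the scatter of each other. Nothing in the measured steps therefore points to a change beyond the scatter for the present swap. Compound 4 is expected to give 8000 nM in this assay, within 4000 nM to 16000 nM, which means an expected step of a 1.1-fold higher number from compound 1 to compound 4 (0.04 log units; within the scatter).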

Compound 4, half-maximal inhibitory concentration: 18200 nM
Compound 4: the middle estimate sits 2.3-fold (0.36 log units) below what was measured; the whole stated range lies below it.
By their numbers in this assay, from the lowest: compounds 1, 2, 3 and 4 (each within the scatter of the next, the first and the last beyond it).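

In this assay, for the compounds shown here, the swap on a saturated chain carbon bound to an aromatic nitrogen gives a 2.5-fold higher number from compound 1 to compound 4 (0.40 log units; beyond the scatter), the first step at this position that lies beyond the scatter, so the choice of aryl group here can register in this read-out. The step of a 1.7-fold higher number from compound 2 to compound 4 (0.24 log units; within the scatter) stays within the scatter, so 3-chlorobenzyl separates from 2-fluorobenzyl but not from cyclopentyl, and compound 2 and compound 4 cannot be ranked against each other. No available evidence bears on the reason for this result.

From the compounds shown here alone, the swap changes the halogen and its place on the ring together, so the contribution of each remains open. A 3-fluorobenzyl group would help to separate the two, while an amine or a carboxylic acid on the benzyl ring remains an open test of this position.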